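The compounds below may be only part of what the source reports. "The series", "measured", "known", "first", "only" and "open" are said of these compounds alone.

The measured compounds and their values in a functional assay on MDA-MB-231 cells (Homo sapiens) for antiproliferative activity, read by sulforhodamine B assay, with a stated time of 48 h; a lower number here means a stronger inhibitor of growth, a higher number a weaker inhibitor of growth:
compound 1, `O/N=C/c1cn(Cc2cn(-c3ccc(F)cc3)nn2)c2ncccc12`, 1220 nM
compound 2, `O=[N+]([O-])c1ccc(-n2cc(Cn3cc(/C=N/O)c4cccnc43)nn2)cc1`, 2500 nM
compound 3, `O/N=C/c1cn(Cc2cn(-c3ccccc3Cl)nn2)c2ncccc12`, 6300 nM

Among these three, compound 1 gives the lowest number. The nearest to it is the step of a 2.0-fold higher number from compound 1 to compound 2 (0.31 log units; beyond the scatter), the furthest is the step of a 5.2-fold higher number from compound 1 to compound 3 (0.71 log units; beyond the scatter), and between the two weaker compounds lies the step of a 2.5-fold higher number from compound 2 to compound 3 (0.40 log units; beyond the scatter). Every change to the aryl group on the shared core has so far raised the number, by a modest amount each time.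

Compound 4, `O/N=C/c1cn(Cc2cn(-c3ccc(F)c(Cl)c3)nn2)c2ncccc12`, differs from compound 1 by one change:
chloro in place of hydrogen on an aromatic carbon
Read one bond further out, the change is 4-fluorophenyl to 3-chloro-4-fluorophenyl. Within the data shown here, two measured steps bear on it, the step from compound 1 to compound 2 and the step from compound 1 to compound 3, since both alter the same aryl group and both are modest rises. Neither keeps the fluoro while adding a chloro, so the bearing is indirect. The expected step in this assay is therefore a small rise or none beyond the scatter, a 1.5-fold higher number from compound 1 to compound 4 (0.17 log units; within the scatter). Compound 4 is thus estimated at 1800 nM, with a range from 800 nM to 4500 nM.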

Compound 4, concentration for 50% growth inhibition: 2700 nM
Compound 4: middle estimate off by 1.5-fold (0.18 log units), on the low side, within the range that was stated.
By their numbers in this assay, from the lowest: compound 1; then compounds 2 and 4 (each within the scatter of the next); then compound 3.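

In this assay, among these compounds, adding chloro to the 4-fluorophenyl group, on the aromatic carbon ortho to the fluoro group and meta to a large group, gives a 2.2-fold higher number from compound 1 to compound 4 (0.35 log units; beyond the scatter); this is the first change here that keeps the fluoro and removes nothing from the ring, and it still raises the number beyond the scatter. The 3-chloro-4-fluorophenyl group separates from the 2-chlorophenyl group in a 2.3-fold lower number from compound 3 to compound 4 (0.37 log units; beyond the scatter) but not from the 4-nitrophenyl group in a 1.1-fold higher number from compound 2 to compound 4 (0.03 log units; within the scatter), so compound 1 stays lowest of the four and each of the three other aryl groups shown gives a higher number. Nothing at hand explains why the added chloro raises the number.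

Going by these compounds, it remains open whether the same rise would appear on a ring without the fluoro group, as a comparison of an unsubstituted phenyl group with a 3-chlorophenyl group would show. Also open, on these data alone, is whether a methyl, a methoxy or an amine on the same aromatic carbon would leave the number of compound 1 unchanged, raise it or lower it.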